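Chloro to bromo on the aryl ring of a hydrazone series

The compounds below may be only part of what the source reports. "The series", "measured", "known", "first", "only" and "open" are said of these compounds alone.

Of the compounds shown here, three sharing one core have been tested in a functional assay on the whole organism for inhibition, with Rattus norvegicus as the target; on this read-out lower numbers stand for an effect already at smaller amounts and higher numbers for an effect only at larger amounts of compound. Compound 1 `CC1CC/C(=N\Nc2ccccc2F)c2ncc(C(=O)O)c(=O)n21` gives 5 umol/kg. Compound 2 `CC1CC/C(=N\Nc2cccc(Cl)c2)c2ncc(C(=O)O)c(=O)n21` gives 0.6 umol/kg, and compound 3 `CC1CC/C(=N\Nc2ccc(Cl)cc2)c2ncc(C(=O)O)c(=O)n21` gives 0.5 umol/kg. Compound 3 thus has the lowest of the three numbers, yet its gap to compound 2 lies within the scatter, so the two cannot be ranked; only compound 1 stands clearly apart, with a step of a 10-fold lower number from compound 1 to compound 3 (1.00 log units; beyond the scatter).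

Compound 4 `CC1CC/C(=N\Nc2ccc(Br)cc2)c2ncc(C(=O)O)c(=O)n21` differs from compound 3 by bromo in place of chloro on an aromatic carbon. Within the data shown here, none of the measured steps exchanges chloro for bromo. The steps of an 8.3-fold lower number from compound 1 to compound 2 (0.92 log units; beyond the scatter) and a 10-fold lower number from compound 1 to compound 3 (1.00 log units; beyond the scatter) each combine a change of atom with a change of place, and the step of a 1.2-fold lower number from compound 2 to compound 3 (0.08 log units; within the scatter) shows that the place of the chloro group alone mattered little. Among the measured compounds shown here, with no direct precedent, the expectation for compound 4 is a number close to that of compound 3, a step of no change at the digits printed from compound 3 to compound 4 (within the scatter) that stays within the scatter. In this assay compound 4 is therefore estimated at 0.5 umol/kg, in a range from 0.2 umol/kg to 1.2 umol/kg.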

Compound 4, dose for 50% inhibition: 0.8 umol/kg
For compound 4 the middle estimate is 1.6-fold (0.20 log units) below the measured one; the range from low to high includes it.
By their numbers in this assay, from the lowest: compounds 3, 2 and 4 (each within the scatter of the next); then compound 1.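

At this place on the aromatic ring, bromo can stand in for chloro with no change that this assay can resolve: the exchange gives a 1.6-fold higher number from compound 3 to compound 4 (0.20 log units; within the scatter). Among these compounds, this is the only direct exchange of one halogen for another at a fixed place, and it adds to the earlier hint that the exact choice of chloro is not critical here. The 4-bromophenyl group also cannot be told apart from the 3-chlorophenyl group, with a 1.3-fold higher number from compound 2 to compound 4 (0.12 log units; within the scatter), while the 2-fluorophenyl group remains the one that stands apart, with a 6.3-fold lower number from compound 1 to compound 4 (0.80 log units; beyond the scatter).

Nothing available here explains these numbers or says why the halogens behave alike. Still open, going by these compounds, is what happens when something other than a halogen takes this place, such as a methoxy group, a trifluoromethyl group or an amine.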